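The source may report more compounds than this note shows. Statements on the series, on what has been measured and on what is new or still open speak of the compounds shown alone.

Measured compounds:
compound 1 `O=C(Nc1ccccc1)Nc1ccc(Oc2ccc(-c3nccs3)cc2)cc1` — "not determined" (no result reported)
compound 2 `O=C(Nc1ccc(Oc2ccc(-c3nccs3)cc2)cc1)Nc1ccc(F)c(C(F)(F)F)c1` — 76.4%
compound 3 `Cc1ccc(NC(=O)Nc2ccc(Oc3ccc(-c4nccs4)cc3)cc2)cc1` — 15.6%

In a functional assay on A549 cells (Homo sapiens) for inhibition, read by MTT assay and WST assay, with a stated time of 72 h, tested at 10 uM (a higher number here means more inhibition of growth at the concentration tested, a lower number less inhibition of growth), compound 2 gives 76.4%, whereas compound 3 gives 15.6%; for compound 1 the result is "not determined" (no result reported). Within the data shown here, compound 3 thus stands lowest of the two numbers available, with compound 2 as its only numbered neighbour, and the step of a number 60.8 percentage points lower from compound 2 to compound 3 (beyond the scatter) is the one measured step.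

Compound 4 `O=C(Nc1ccc(Oc2ccc(-c3nccs3)cc2)cc1)Nc1cc(C(F)(F)F)ccc1Cl` differs from compound 3 in one place: 2-chloro-5-(trifluoromethyl)phenyl in place of 4-methylphenyl on an amide-type nitrogen. Among the measured compounds shown here, the only measured step that bears on this change is a number 60.8 percentage points lower from compound 2 to compound 3 (beyond the scatter), in which a 4-methylphenyl replaced a halogenated aryl on the same amide-type nitrogen and the number fell sharply. Compound 4 reverses that kind of exchange, since it brings a trifluoromethyl-bearing, chlorine-bearing aryl back onto that nitrogen, though not the same one as in compound 2. A step upward from compound 3 is therefore expected in this assay, and compound 4 is estimated at 60%, within 30% to 85%, which would mean an expected step of a number 44.4 percentage points higher from compound 3 to compound 4 (beyond the scatter).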

Compound 4, percent growth inhibition at one concentration: 75.5%
Compound 4: the middle estimate sits 15.5 percentage points below what was measured; measured number inside the range.
By their numbers in this assay, from the lowest: compound 3; then compounds 4 and 2 (each within the scatter of the next).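

In this assay, the step of a number 59.9 percentage points higher from compound 3 to compound 4 (beyond the scatter) shows that the high number of compound 2 is not tied to one particular aryl group on this amide-type nitrogen, since a second aryl carrying both trifluoromethyl and a halogen also stands far from the 4-methylphenyl of compound 3. The step of a number 0.9 percentage points lower from compound 2 to compound 4 (within the scatter) leaves 2-chloro-5-(trifluoromethyl)phenyl and 4-fluoro-3-(trifluoromethyl)phenyl level with each other, so among the numbered compounds only compound 3 stands apart, and none goes against this grouping. No measurement given here accounts for the gap between these aryl groups and 4-methylphenyl.

The compounds shown leave open whether trifluoromethyl alone or a halogen alone on this aryl ring would keep the number high, and what an amine or a carboxylic acid on that ring would do. Steps involving compound 1 cannot be read, its entry being "not determined" (no result reported), so the plain phenyl group gives no baseline for this nitrogen.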